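The source may report more compounds than this note shows. Statements on the series, on what has been measured and on what is new or still open speak of the compounds shown alone.

Working notes on the series.

For the measured compounds named here, compound 1 `COc1cc2ccc(=O)oc2cc1OCCCOc1no[n+]([O-])c1S(=O)(=O)c1ccccc1` is one of two compounds measured so far in a functional assay on A549 cells (Homo sapiens) for inhibition, read by MTT assay, with a stated time of 48 h; on this read-out higher numbers stand for weaker inhibition and lower numbers for stronger inhibition. In this assay compound 1 gives 5450 nM. Going by the values given here, the second measured compound, compound 2 `COc1cc2ccc(=O)oc2cc1OCCCCCOc1c[n+]([O-])on1`, differs from compound 1 in more than one place, so no single step between the two is counted; in this assay compound 2 gives 10600 nM. The two numbers lie within the usual scatter of each other, so compound 1 stands at one end of a pair that cannot be told apart on the present data, and no ordering of the two is claimed.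

The next compound, compound 3 `COc1cc2cc(N)c(=O)oc2cc1OCCCOc1no[n+]([O-])c1S(=O)(=O)c1ccccc1`, carries the shared core of compound 1 with one change: amino in place of hydrogen on an aromatic carbon. Among the compounds with values here, nothing among the measured compounds shows what such a change does in this assay, so the size and direction of the step can only be guessed. The expectation is a step from compound 1 of a 1.1-fold lower number from compound 1 to compound 3 (0.04 log units; within the scatter), small enough that it need not exceed the scatter. On that basis compound 3 is estimated at 5000 nM, with a range from 1500 nM to 16000 nM.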

Compound 3, half-maximal inhibitory concentration: 4180 nM
The estimate for compound 3 lay 1.2-fold (0.08 log units) above the measured number; the range from low to high includes it.
By their numbers in this assay, from the lowest: compounds 3, 1 and 2 (each within the scatter of the next, the first and the last beyond it).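

In this assay, for the compounds shown here, amino in place of hydrogen on an aromatic carbon gives a 1.3-fold lower number from compound 1 to compound 3 (0.12 log units; within the scatter), so the first single-place step does not separate compound 3 from compound 1. The earlier compounds shown here held no measurement of any change at this place, on the six-membered aromatic ring with 1 oxygen and two atoms from the ring oxygen; the pair now shows that this place can carry an amino group with no step beyond the scatter on this read-out. Nothing available bears on why the step has this size, and none of the data shown speaks to the role of the amino group in this result.

On these data alone, whether another group at the same place, such as a hydroxyl, a methyl, an acetamide or a carboxylic acid, would give a step beyond the scatter remains open. Also open, as far as these compounds go, is whether the same exchange of hydrogen for amino on the core of compound 2, or with a longer chain on the core of compound 1, would give a step of similar size.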